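Three Amides on One Core, and a Fourth to Come

The source may hold more compounds than are shown below. What is called first, only, known or untested is meant among the compounds shown, and "the series" means these compounds.

Compound 1 `C#CCNC(=O)/C=C/c1c(/C=C/c2ccc(OC)cc2)cc(OC)cc1OC`: 6930 nM
Compound 2 `CCC(C)NC(=O)/C=C/c1c(/C=C/c2ccc(OC)cc2)cc(OC)cc1OC`: 3950 nM
Compound 3 `COc1ccc(/C=C/c2cc(OC)cc(OC)c2/C=C/C(=O)N2CCCC(C)C2)cc1`: 5820 nM

In a functional assay on A549 cells (Homo sapiens) for inhibition, read by MTT assay, with a stated time of 48 h (a higher number here means a weaker inhibitor, a lower number a stronger inhibitor), the three measured compounds give compound 1 6930 nM, compound 2 3950 nM and compound 3 5820 nM. Compound 2 gives the lowest number of the three, but the steps of a 1.8-fold lower number from compound 1 to compound 2 (0.24 log units; within the scatter) and a 1.5-fold higher number from compound 2 to compound 3 (0.17 log units; within the scatter) both stay within the scatter, so none of the three can be set apart from the others, and the step of a 1.2-fold lower number from compound 1 to compound 3 (0.08 log units; within the scatter) also stays within it.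

Compound 4 `COc1ccc(/C=C/c2cc(OC)cc(OC)c2/C=C/C(=O)N2CCN(C)CC2)cc1` has not yet been measured in this assay. It differs from compound 2 by 4-methylpiperazin-1-yl in place of (sec-butyl)amino on a carbonyl carbon. The step that bears most on it is a 1.5-fold higher number from compound 2 to compound 3 (0.17 log units; within the scatter), where the (sec-butyl)amino group likewise gave way to a six-membered ring on the carbonyl carbon; the step of a 1.2-fold lower number from compound 1 to compound 3 (0.08 log units; within the scatter), also leading to a ring amide, points the same way. Both were within the scatter. A step within the scatter is therefore expected, if anything toward a slightly higher number, so that a 1.5-fold higher number from compound 2 to compound 4 (0.18 log units; within the scatter) is the expectation. Compound 4 is thus estimated at 6000 nM, in a range from 2500 nM to 15000 nM.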

Compound 4, half-maximal inhibitory concentration: 4510 nM
Compound 4: the middle estimate sits 1.3-fold (0.12 log units) above what was measured, and the stated range covers the measured number.
By their numbers in this assay, from the lowest: compounds 2, 4, 3 and 1 (each within the scatter of the next).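

Placing 4-methylpiperazin-1-yl on the carbonyl carbon (a 1.1-fold higher number from compound 2 to compound 4 (0.06 log units; within the scatter)) in this assay shows that this position accepts a ring with two hetero atoms and no hydrogen-bond donor without a step beyond the scatter, a change that compound 3, with its 3-methylpiperidin-1-yl ring, had not tested. The exchange between the two ring amides (a 1.3-fold lower number from compound 3 to compound 4 (0.11 log units; within the scatter)) and the step from the propargylamino amide (a 1.5-fold lower number from compound 1 to compound 4 (0.19 log units; within the scatter)) also stay within the scatter, so all four groups at this position now give numbers that cannot be told apart, whether the group is open-chain or a ring. No measurement shown here offers an explanation for this flat result.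

As far as these compounds go, what remains open is whether any change at this carbonyl carbon can move the number beyond the scatter, since the four compounds span only a narrow band and none can be set apart. A morpholine ring, a chain ending in a carboxylic acid or a primary amine, or a much longer alkyl chain on the amide nitrogen would test that, as would a change elsewhere on the shared core.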